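Cyclopropenyl purine diols: cytotoxicity, propylamino to propoxy

The source may report more compounds than this note shows. Statements on the series, on what has been measured and on what is new or still open speak of the compounds shown alone.

Measured compounds:
- compound 1 `CN(C)c1nc(N)nc2c1ncn2/C=C1/CC1(CO)CO`: in an ADME assay on BCBL1 cells (Homo sapiens) for cytotoxicity, with a stated time of 7 days (a lower number here means that less compound is tolerated, a higher number that more compound is tolerated), compound 1 gives > 20000 nM, which is a limit of the assay.
- compound 2 `Nc1nc(NC2CC2)c2ncn(/C=C3/CC3(CO)CO)c2n1`: in this assay compound 2 gives 71500 nM.
- compound 3 `CCCNc1nc(N)nc2c1ncn2/C=C1/CC1(CO)CO`: in this assay compound 3 gives > 20000 nM, again a limit of the assay.

Among the measured compounds shown here, compound 3 thus stands only at a limit, and only one other value in the set is a number. The three measured steps, a step that the limit leaves unreadable from compound 1 to compound 2, a step that the two limits leave unreadable from compound 1 to compound 3 and a step that the limit leaves unreadable from compound 2 to compound 3, are all left unreadable, because of the limit of > 20000 nM in this assay, at which 2 of the 3 values shown sit. None of them therefore gives a size against which a new step can be scaled.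

The next compound is compound 4 `CCCOc1nc(N)nc2c1ncn2/C=C1/CC1(CO)CO`. Its difference from compound 3 is propoxy in place of propylamino on an aromatic carbon, the group sitting on the aromatic carbon of the shared core described above. For the measured compounds named here, no measured step touches this kind of change, and the measured steps that do exist have no readable size. The expectation is therefore neutral: no step beyond the scatter in either direction, with a sizeable chance that the assay again reports only a limit.

Compound 4 is estimated to give 40000 nM in this assay, within 15000 nM to 120000 nM. The step this estimate implies, a step that the limit leaves unreadable from compound 3 to compound 4, is expected to stay within the scatter.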

Compound 4, half-maximal cytotoxic concentration: > 20000 nM
Compound 4: no number, only a limit (the forecaster's own chance of this, stated with the estimate: 60%); the middle value lies beyond the limit too.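

Among the compounds shown here, no step from compound 1, compound 2 or compound 3 to compound 4 can be read, because of this: the limit of > 20000 nM in this assay, at which 3 of the 4 values shown sit.

As far as these compounds go, whether propoxy in place of propylamino on an aromatic carbon changes the half-maximal cytotoxic concentration, in either direction, remains open.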